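The source may report more compounds than this note shows. Statements on the series, on what has been measured and on what is new or still open speak of the compounds shown alone.

Measured compounds:
Compound 1, `Cc1nc(-c2ccccc2)c(C(=O)N2CCN(c3cccc(Cl)c3Cl)CC2)o1`: 133 nM
Compound 2, `COc1cc(OC)cc(N2CCN(C(=O)c3onc(C)c3-c3ccccc3)CC2)c1`: 152 nM
Compound 3, `CCc1nc(-c2ccc(OC)cc2)c(C(=O)N2CCN(c3cccc(Cl)c3)CC2)o1`: > 1000 nM

In a functional assay on HL-60 cells (Homo sapiens) for inhibition, read by MTT assay, with a stated time of 72 h (on this read-out higher numbers stand for weaker inhibition and lower numbers for stronger inhibition), compound 1 gives 133 nM, the lowest of the two numbers measured. Compound 2 gives 152 nM, and its gap to compound 1 lies within the scatter, so no order can be drawn between the two. Compound 3 returns only a limit, > 1000 nM, which is the limit of > 1000 nM in this assay, at which 1 of the 3 values shown sits. Going by the values given here, no step between two measured compounds that differ in a single place has been recorded, so the measured set gives no direct guide to what any single change does.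

The account turns to compound 4, `Cc1nc(-c2ccccc2)c(C(=O)N2CCN(c3c(C)cccc3C)CC2)o1`, not yet measured. It differs from compound 1 by 2,6-dimethylphenyl in place of 2,3-dichlorophenyl on an amine nitrogen in a ring. Among the compounds with values here, with no measured step of this kind to lean on, a change of moderate size at most is expected in this assay, in either direction, and most likely none beyond the scatter. Compound 4 is estimated at 200 nM, within a range from 70 nM to 700 nM, so the expected step of a 1.5-fold higher number from compound 1 to compound 4 (0.18 log units; within the scatter) is small.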

Compound 4, half-maximal inhibitory concentration: 146 nM
Beside the measured number, compound 4's estimate is 1.4-fold (0.14 log units) above it, and the stated range covers the measured number.
By their numbers in this assay, from the lowest: compounds 1, 4 and 2 (each within the scatter of the next). At a limit, above all of these: compound 3.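

The first step recorded at this place, on an amine nitrogen in a ring, shows that in this assay 2,6-dimethylphenyl can take the place of 2,3-dichlorophenyl with a 1.1-fold higher number from compound 1 to compound 4 (0.04 log units; within the scatter), so the number does not move beyond the scatter. Compound 4 carries no chlorine, so on the core of compound 1 chlorine on this phenyl group is not required for a number of this size. Why the two groups read alike cannot be told from what is on hand, as nothing measured here speaks to a cause.

Still open, from the compounds shown here alone, is whether this place tolerates a phenyl group bearing a nitrile, an amine or a carboxylic acid as it tolerates the two groups compared here, or whether the number would then move beyond the scatter. Also open, going by these compounds, is what a single change elsewhere on the core of compound 1 does, such as a propyl chain in place of its methyl group, since this one step speaks only to the phenyl group on the ring nitrogen.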